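Removing the hydroxyl from compound 2: expected inhibition

The compounds below may be only part of what the source reports. "The series", "measured", "known", "first", "only" and "open" are said of these compounds alone.

Measured so far:
compound 1, `CC(Sc1nc2c(cnn2C)c(=O)n1-c1ccccc1)c1ccccn1`, 97%
compound 2, `CC(Sc1nc2c(cnn2C)c(=O)n1-c1ccccc1)c1cccc(O)c1`, 61%

Both numbers come from an assay on PEO1 cells for inhibition of Retinaldehyde dehydrogenase 3 (Homo sapiens), read by flow cytometry, with a stated time of 30 min, tested at 1 uM; on this read-out higher numbers stand for more inhibition at the one concentration tested (going by the name of the read-out) and lower numbers for less inhibition. Compound 2 stands lowest of the two measured compounds; its nearest neighbour, compound 1, lies higher by the step of a number 36 percentage points lower from compound 1 to compound 2 (beyond the scatter), which is beyond the scatter. Compound 3, `C[C@H](Sc1nc2c(cnn2C)c(=O)n1-c1ccccc1)c1ccccc1`, is not yet measured. It differs from compound 2 by a group of 8 heavy atoms (8 carbon; one six-membered aromatic ring of carbon only) in place of a group of 9 heavy atoms (8 carbon, 1 oxygen; one six-membered aromatic ring of carbon only), on a sulfur: a 1-phenylethyl group enters in place of the hydroxyl-bearing ring, and the new group carries one defined stereocentre. Among the compounds with values here, the only measured step, from compound 1 to compound 2, swaps one aromatic ring for another at the same place and was large, so changes on this part of the molecule can move the read-out considerably. Within the data shown here, no measured pair shows what loss of the hydroxyl alone does, so the direction is uncertain. The estimate for compound 3 in this assay is 70%, with a range from 40% to 95%; this expected step is a number 9 percentage points higher from compound 2 to compound 3 (within the scatter).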

Compound 3, a percentage reported as inhibition, at one concentration (the size of the read-out at that concentration, not a potency): 2%
Compound 3: middle estimate off by 68 percentage points, on the high side, and the stated range ends above it.
By their numbers in this assay, from the lowest: compound 3; then compound 2; then compound 1.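

In this assay the plain 1-phenylethyl group on the sulfur gives a number 59 percentage points lower from compound 2 to compound 3 (beyond the scatter) and also a number 95 percentage points lower from compound 1 to compound 3 (beyond the scatter) in a second comparison with the same group. The result shows that a bare carbon ring at this place is no neutral starting point: among these three compounds, the two whose ring carries a nitrogen or a hydroxyl keep clear inhibition, and none goes against this. Nothing measured here explains the loss.

On these data alone, compound 3 has one defined stereocentre while compounds 1 and 2 are drawn without one, so the behaviour of its mirror-image form remains open. Also open, as far as these compounds go, is whether a methoxy group on the phenyl ring, or a pyridin-3-yl ring, would bring inhibition back.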